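Compound 3 to compound 4: a larger group

The source may report more compounds than this note shows. Statements on the series, on what has been measured and on what is new or still open speak of the compounds shown alone.

Measured in a physicochemical assay for solubility, in phosphate buffer, at pH 7.4; a lower number here means a less soluble compound, a higher number a more soluble compound:
- compound 1 `CC(=O)N[C@@H]1CCC[C@H](C(=O)Nc2cc(-c3cnn4c3CCCC4)ccn2)C1`: 730000 nM
- compound 2 `CC(=O)N[C@@H]1CCC[C@H](C(=O)Nc2cc(-c3cnn4c3CCCC4)c(F)cn2)C1`: > 1000000 nM (a limit of the assay)
- compound 3 `CC(=O)N[C@@H]1CCC[C@H](C(=O)Nc2cc(-c3cnc(C)n3C)c(Cl)cn2)C1`: > 1000000 nM (a limit of the assay)

Compound 3 has no number, only > 1000000 nM, which is a limit of the assay. It therefore stands at the limit of > 1000000 nM in this assay, at which 2 of the 3 values shown sit.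

Compound 4 `CC(=O)N[C@@H]1CCC[C@H](C(=O)Nc2cc(-c3cnn4c3CCCCC4)c(Cl)cn2)C1` is not yet measured. Its structural change is a group of 10 heavy atoms (8 carbon, 2 nitrogen; one five-membered aromatic ring with 2 hetero atoms, one seven-membered non-aromatic ring with 1 hetero atom) in place of a group of 7 heavy atoms (5 carbon, 2 nitrogen; one five-membered aromatic ring with 2 hetero atoms), on an aromatic carbon, ortho to a chloro group.

One measured step exists: an at least 1.3-fold higher number from compound 1 to compound 2 (0.13 log units; that floor lies within the scatter). It bears on this change only loosely, as it is a fluoro in place of hydrogen on an aromatic carbon and leaves the group in question untouched. Among the compounds with values here, no measured step exchanges that group. Within the data shown here, the closest guide is compound 1 at 730000 nM, which carries a group much like the entering one and gives the only number.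

In this assay no step beyond the scatter is expected, and any shift would be downward. The expected step is an at least 1.4-fold lower number from compound 3 to compound 4 (0.15 log units; that floor lies within the scatter). For compound 4 the estimated value is 700000 nM, with an expected range from 200000 nM to 1000000 nM. A reading at the limit would not be a surprise.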

Compound 4, solubility: 104000 nM
Estimate against measurement, compound 4: 6.7-fold (0.83 log units) above, outside the stated range (below it).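

In this assay, the group with one five-membered aromatic ring and one seven-membered non-aromatic ring, placed ortho to a chloro group in exchange for 1,2-dimethyl-1H-imidazol-5-yl, gives an at least 9.6-fold lower number from compound 3 to compound 4 (0.98 log units; beyond the scatter) and so provides the first step in the series shown that lies beyond the scatter. Compound 3 carries only > 1000000 nM, which is a limit of the assay. The size of the step remains a floor, with the true gap open on the upper side, because compound 3 sits at that limit: the limit of > 1000000 nM in this assay, at which 2 of the 4 values shown sit.

The single exchange does not separate the contribution of the seven-membered non-aromatic ring from that of the change in the five-membered aromatic ring, since the two groups differ in both parts and no compound shown carries one part without the other. Also open, on these data alone, is how this assay would read for this chloro-bearing core with a morpholine or a carboxylic acid attached to the entering group, which would show whether the lower number can be recovered at this position.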